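The source may hold more compounds than are shown below. What is called first, only, known or untested is meant among the compounds shown, and "the series" means these compounds.

Compound 1 `CCN1CCN(CCC(=O)Nc2nc3c(C)cccc3s2)CC1` is the reference point of this small set. In an assay on membranes from liver for displacement of a labelled ligand from Sigma intracellular receptor 2 (Rattus norvegicus), read by scintillation counting, with a stated time of 120 min (a lower number here means a stronger inhibitor, a higher number a weaker inhibitor), compound 1 gives 1200 nM, the highest of the two numbers recorded; the nearest is compound 2 `Cc1cccc2sc(NC(=O)CCN3CCN(CCN(C(C)C)C(C)C)CC3)nc12`, which gives 121 nM, and the step of a 9.9-fold lower number from compound 1 to compound 2 (1.00 log units; beyond the scatter) adds diisopropylamino in place of hydrogen on a saturated chain carbon, two bonds along the chain from an amine nitrogen in a ring. Compound 3 `Cc1ccccc1N1CCN(CCC(=O)Nc2nc3c(C)cccc3s2)CC1` is reported only as a limit in this assay, > 1000 nM. The step that the limit leaves unreadable from compound 1 to compound 3 therefore cannot be sized, and an at least 8.2-fold higher number from compound 2 to compound 3 (0.91 log units; beyond the scatter) is read only as a lower bound; both rest on (the limit of > 1000 nM in this assay, at which 1 of the 3 values shown sits).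

Compound 4 `Cc1cccc2sc(NC(=O)CCN3CCN(c4ncccn4)CC3)nc12` is not yet measured. It differs from compound 1 by pyrimidin-2-yl in place of ethyl on an amine nitrogen in a ring. Within the data shown here, the change sits on the same ring nitrogen as the one that took 2-methylphenyl in compound 3, the only measured step at that position, which was not readable but pointed to a weaker end. Among the measured compounds shown here, no measured step at that position shows a gain. The expectation for compound 4 is therefore a number near or somewhat above that of compound 1, with a sizeable chance of another limit. Compound 4 is estimated at 2000 nM, with a range from 600 nM to 7000 nM. The expected step is a 1.7-fold higher number from compound 1 to compound 4 (0.22 log units; within the scatter).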

Compound 4, inhibition constant: > 1000 nM
Compound 4 ended at the assay's limit; the forecaster's own chance of this, stated with the estimate: 45%; the middle value lies beyond the limit too.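

In this assay compound 4 gives > 1000 nM, a limit and not a number, so a second group with an aromatic ring set directly on this ring nitrogen, after the 2-methylphenyl of compound 3, also gives no readable value. Among these compounds, replacing 2-(diisopropylamino)ethyl with pyrimidin-2-yl gives an at least 8.2-fold higher number from compound 2 to compound 4 (0.91 log units; beyond the scatter), and 2-(diisopropylamino)ethyl stays the only group on this nitrogen with a number clearly lower than that of compound 1. The steps to compound 4 from the other two compounds cannot be read: the limit of > 1000 nM in this assay, at which 2 of the 4 values shown sit.

From the compounds shown here alone, how pyrimidin-2-yl and 2-methylphenyl compare remains open. So does whether the gain in compound 2 follows the diisopropylamino end or the two-carbon chain itself, which a dimethylamino or pyrrolidine end, or a longer chain, on this nitrogen would separate.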